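A few compounds are considered here, and "the series" means these few. Any claim that something is new, unique, unknown or untested is made for them only; others in the source may bear on it.

Measured compounds:
Compound 1, `O=C(CSc1snnc1-c1ccc(Br)cc1Br)Nc1ccccc1[N+](=O)[O-]`, gives in an ADME assay on MT4 cells (Homo sapiens) for cytotoxicity, read by MTT assay, with a stated time of 5 days (a lower number here means that less compound is tolerated, a higher number that more compound is tolerated), a value of > 235000 nM, which is a limit of the assay and not a number.
Compound 2, `Cc1cccc(C)c1NC(=O)CSc1snnc1-c1ccc(Br)cc1Br`, gives in this assay a value of >= 198000 nM, again a limit of the assay.
Compound 3, `Cc1ccc(NC(=O)CSc2snnc2-c2ccc(Br)cc2Br)c(Br)c1`, gives in this assay a value of > 216000 nM, also a limit of the assay.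

Among the compounds with values here, compound 1 thus stands only at a limit in this assay, and the two further values shown are limits as well, so no compound here has a measured number. The step of interest leads to compound 4, `COC(=O)c1ccsc1NC(=O)CSc1snnc1-c1ccc(Br)cc1Br`, which has not yet been measured. The change is 3-(methoxycarbonyl)thiophen-2-yl in place of 2-nitrophenyl on an amide-type nitrogen.

Within the data shown here, three measured steps bear on the same position on the amide-type nitrogen: a step that the two limits leave unreadable from compound 1 to compound 2, a step that the two limits leave unreadable from compound 1 to compound 3 and a step that the two limits leave unreadable from compound 2 to compound 3. Each of them is unreadable, since both ends sit at a limit. Three swaps of the group on that nitrogen left every compound at a limit, so a fourth swap is expected to do the same, with no readable step beyond the scatter.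

For compound 4 in this assay the estimate is 220000 nM, within 100000 nM to 500000 nM. The step of an at least 1.0-fold lower number from compound 1 to compound 4 (0.02 log units; that floor lies within the scatter) is therefore expected to be small, and most likely only another limit will be reported.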

Compound 4, half-maximal cytotoxic concentration: > 227000 nM
Compound 4: no number, only a limit (the forecaster's own chance of this, stated with the estimate: 85%); middle value at least 1.0-fold (0.01 log units) from the limit.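

Compound 4 stops at a limit in this assay and gives no number, just as compound 1, compound 2 and compound 3 do, so none of the steps to compound 4 can be read. The compounds shown leave open at what concentration any of the four harms the cells, and whether the group on the amide-type nitrogen changes that concentration at all.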